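The compounds below may be only part of what the source reports. "The series", "measured", "known", "first", "only" and "open" are said of these compounds alone.

Compound 1 `Nc1ccccc1NC(=O)c1ccc(NC(=S)NCc2cccc(F)c2)cc1`: 74000 nM
Compound 2 `Nc1ccccc1NC(=O)c1ccc(NC(=S)NCc2cncc(F)c2)cc1`: 85000 nM
Compound 3 `Nc1ccccc1NC(=O)c1ccc(NC(=O)NCc2ccc(Cl)nc2)cc1`: 34000 nM

In a functional assay on MDA-MB-231 cells (Homo sapiens) for cytotoxicity, read by MTT assay, with a stated time of 72 h (a lower number here means a stronger inhibitor, a higher number a weaker inhibitor), compound 3 gives 34000 nM, the lowest of the three numbers and lower than those of compound 1 and compound 2 by more than the usual scatter. Compound 4 `Nc1ccc(CNC(=O)Nc2ccc(C(=O)Nc3ccccc3N)cc2)cn1` has not yet been measured. It differs from compound 3 in one place, with amino in place of chloro on an aromatic carbon, so that 6-chloropyridin-3-yl becomes 6-aminopyridin-3-yl.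

For the measured compounds named here, only one measured step is available as a guide, a 1.1-fold higher number from compound 1 to compound 2 (0.06 log units; within the scatter). It puts 5-fluoropyridin-3-yl in place of 3-fluorophenyl, so it shows a change in the same part of the molecule, but not this exchange. It stays within the scatter. Going by the values given here, no measured pair swaps chloro for amino, so the data give no firm direction, and no step beyond the scatter is expected. The estimated change is a 1.3-fold higher number from compound 3 to compound 4 (0.12 log units; within the scatter). For compound 4 the expected value is 45000 nM, with an estimated range from 15000 nM to 120000 nM.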

Compound 4, half-maximal inhibitory concentration: > 100000 nM
Compound 4: only a limit was reported (the forecaster's own chance of this, stated with the estimate: 10%); at least 2.2-fold (0.34 log units) between middle value and limit.
By their numbers in this assay, from the lowest: compound 3; then compounds 1 and 2 (each within the scatter of the next). At a limit, above all of these: compound 4.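

For the compounds shown here, the chloro position of compound 3 proves sensitive to a one-atom exchange: in this assay, amino in place of chloro gives an at least 2.9-fold higher number from compound 3 to compound 4 (0.46 log units; beyond the scatter), whereas the only earlier step in this part of the molecule, a 1.1-fold higher number from compound 1 to compound 2 (0.06 log units; within the scatter), did not move the number beyond the scatter. Compound 4 is reported only as a limit, > 100000 nM, so its step has a floor but no known size. The one further fact on record concerns that limit: the limit of > 100000 nM in this assay, at which 1 of the 4 values shown sits.

As far as these compounds go, whether a methyl, a methoxy or a dimethylamino group at this place would stay close to compound 3 or behave like amino remains open. The compounds shown also do not tell why the number rises, or whether the same exchange would have a similar effect on compound 1.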